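The source may hold more compounds than are shown below. What is called first, only, known or untested is meant among the compounds shown, and "the series" means these compounds.

Measured in a functional assay on KB cells (Homo sapiens) for inhibition; a higher number here means a weaker inhibitor, a lower number a stronger inhibitor:
- compound 1 `Nc1nc2cc(Cl)c(Cl)cc2n1Cc1ccc(Cl)cc1`: 45000 nM
- compound 2 `Clc1ccc(Cn2c(Cl)nc3cc(Cl)c(Cl)cc32)cc1`: > 100000 nM (a limit)
- compound 3 `Clc1cc2nc(Br)n(Cc3ccccc3)c2cc1Cl`: > 100000 nM (a limit)

Compound 3 gives > 100000 nM, which is a limit of this assay and not a number. Compound 4 `Clc1ccc(Cn2c(Br)nc3cc(Cl)c(Cl)cc32)cc1` differs from it by one change: chloro in place of hydrogen on an aromatic carbon. This puts a chloro in place of hydrogen on an aromatic carbon, para to a large group.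

For the measured compounds named here, no measured step shows this change. Going by the values given here, the only measured step is an at least 2.2-fold higher number from compound 1 to compound 2 (0.34 log units; beyond the scatter), and since it replaces amino rather than hydrogen, it bears on this question only indirectly. Compound 2 already carries the entering chloro, and it gives > 100000 nM, also a limit. Compound 1 carries that chloro as well and gives 45000 nM.

The expectation therefore rests on (the limit of > 100000 nM in this assay, at which 2 of the 3 values shown sit), and no step beyond the scatter is expected in this assay. The expected size is a number no higher from compound 3 to compound 4 (the limit leaves the size open). Compound 4 is estimated at 100000 nM, with an expected range from 40000 nM to 250000 nM.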

Compound 4, half-maximal inhibitory concentration: > 100000 nM
Compound 4: no number, only a limit; the forecaster's own chance of this, stated with the estimate: 70%; the middle value sits exactly at the limit.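

In this assay compound 4 gives > 100000 nM, which is a limit of the assay and not a number. The steps to compound 4 from compound 3 and from compound 2 cannot be read, so the entering chloro, para to a large group, shows no effect that can be sized here. What compound 4 adds is that bromo in place of amino gives an at least 2.2-fold higher number from compound 1 to compound 4 (0.34 log units; beyond the scatter), which matches the direction of chloro in place of amino, an at least 2.2-fold higher number from compound 1 to compound 2 (0.34 log units; beyond the scatter), and leaves compound 1 as the only compound shown with a number: the limit of > 100000 nM in this assay, at which 3 of the 4 values shown sit.

From the compounds shown here alone, whether the entering chloro changes anything in a compound that stays off the limit remains open. So does what a methylamine or a carboxylic acid would give in place of the bromo.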